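Fluoro on the fused ring of compound 2

This account rests on a few compounds, and the source may have more. Where it says the series, first, only, none or still open, it means among the compounds named here.

Compound 1 `CC(c1ccc2nc(-c3cnn(C)c3)ccc2c1)n1nnc2ncc(-c3ccc(N)cc3)nc21` gives "not determined" (no result reported) in a functional assay on SNU-5 cells (Homo sapiens) for inhibition, read by CCK-8 assay, with a stated time of 72 h; on this read-out lower numbers stand for stronger inhibition and higher numbers for weaker inhibition. For the measured compounds named here, compound 2 `CC(c1ccc2ncc(-c3cnn(C)c3)cc2c1)n1nnc2ncc(-c3ccc(C(N)=O)c(F)c3)nc21` gives 0.7 nM and compound 3 `CC(c1ccc2ncc(-c3cnn(C)c3)cc2c1)n1nnc2ncc(-c3ccncc3)nc21` gives 1.2 nM, so compound 2 holds the lowest of the two numbers, with compound 3 within the scatter of it; the move a 1.7-fold higher number from compound 2 to compound 3 (0.23 log units; within the scatter) is the only single-point step available, and it touches the aryl on the other end of the molecule. Compound 4 `CC(c1cc2cc(-c3cnn(C)c3)cnc2cc1F)n1nnc2ncc(-c3ccc(C(N)=O)c(F)c3)nc21` differs from compound 2 by fluoro in place of hydrogen on an aromatic carbon, on an aromatic carbon of the fused two-ring system. Going by the values given here, no measured step bears on this position, so nothing beyond the scatter is expected, the step being estimated as a 1.4-fold higher number from compound 2 to compound 4 (0.15 log units; within the scatter). Compound 4 is thus expected near 1 nM, within 0.35 nM to 3 nM.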

Compound 4, half-maximal inhibitory concentration: 0.6 nM
Compound 4: middle estimate off by 1.7-fold (0.22 log units), on the high side; low and high end bracket the measured number.
By their numbers in this assay, from the lowest: compounds 4, 2 and 3 (each within the scatter of the next).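

Fluoro in place of hydrogen on this aromatic carbon of the fused two-ring system, ortho to a large group, is accommodated in this assay without a step beyond the scatter: a 1.2-fold lower number from compound 2 to compound 4 (0.07 log units; within the scatter). For the compounds shown here, the earlier step touched only the aryl on the other end of the molecule, so this is the only reading at this position. Nothing available explains the result.

From the compounds shown here alone, whether an amine, methoxy or trifluoromethyl on this carbon also stays within the scatter remains open. Also open, going by these compounds, is whether fluoro here gives the same result with the pyridin-4-yl of compound 3.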